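The source may report more compounds than this note shows. Statements on the series, on what has been measured and on what is new or still open speak of the compounds shown alone.

In an in vitro assay on CHO cells for inhibition of B1 bradykinin receptor (Homo sapiens) (on this read-out lower numbers stand for stronger inhibition and higher numbers for weaker inhibition), three compounds of one series have been measured. Compound 1 `COC(=O)c1ccccc1-c1ccc([C@@H](C)Nc2nccc(C)c2NC(=O)CC#N)cc1` gives 2.6 nM. Compound 2 `CNC(=O)c1ccccc1-c1ccc([C@@H](C)Nc2nccc(C)c2NC(=O)CC(F)(F)F)cc1` gives 6 nM. Compound 3 `COC(=O)c1ccccc1-c1ccc(CNc2nccc(C)c2NC(=O)CC(F)(F)F)cc1` gives 7.1 nM, the highest of the three numbers; its gap to compound 2 lies within the usual scatter of this assay, while its gap to compound 1 lies beyond it.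

Compound 4 `COC(=O)c1ccccc1-c1ccc([C@@H](C)Nc2nccc(C)c2NC(=O)CC(F)(F)F)cc1` differs from compound 3 in one place only: methyl in place of hydrogen on a saturated chain carbon bound to an aromatic carbon and a nitrogen on an aromatic ring. The methyl entering here is the same methyl that compounds 1 and 2 already carry on that chain carbon, and both of those compounds sit at lower numbers than compound 3. Within the data shown here, no step between two measured compounds isolates this single change, so nothing can be read off directly.

For compound 4, a step from compound 3 of a 2.0-fold lower number from compound 3 to compound 4 (0.31 log units; beyond the scatter) toward a lower number is expected, modest and close to the edge of the scatter. Compound 4 is therefore estimated at 3.5 nM, within a range from 1.2 nM to 10 nM.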

Compound 4, inhibition constant: 1.8 nM
The estimate for compound 4 lay 1.9-fold (0.29 log units) above the measured number; low and high end bracket the measured number.
By their numbers in this assay, from the lowest: compounds 4 and 1 (each within the scatter of the next); then compounds 2 and 3 (each within the scatter of the next).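

In this assay, among these compounds, methyl in place of hydrogen on the saturated chain carbon gives a 3.9-fold lower number from compound 3 to compound 4 (0.60 log units; beyond the scatter) and this is the first step to isolate that single change, showing that it alone moves the number beyond the scatter. The same compound also opens two comparisons at other places: methoxy in place of methylamino on a carbonyl carbon gives a 3.3-fold lower number from compound 2 to compound 4 (0.52 log units; beyond the scatter) and stays beyond the scatter, while trifluoromethyl in place of cyano gives a 1.4-fold lower number from compound 1 to compound 4 (0.16 log units; within the scatter) and stays within it, so these two groups are not told apart here. No measurement shown gives a reason for any of these steps.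

As far as these compounds go, whether an ethyl group or a longer chain on this carbon would keep the lower number remains open. So does whether the methyl step would be the same in compounds carrying methylamino or cyano.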